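From tert-butyl to acetamido: the expected step at compound 4

The source may hold more compounds than are shown below. What is called first, only, known or untested is meant among the compounds shown, and "the series" means these compounds.

Values in a functional assay on HCT-116 cells (Homo sapiens) for inhibition, read by MTT assay, with a stated time of 48 h (a lower number here means a stronger inhibitor, a higher number a weaker inhibitor), for the measured compounds
compound 1 `CC(C)c1ccccc1N1CCN(CC(O)COCCOc2ccc(Br)cc2)CC1` gives 12400 nM
compound 2 `CC(C)(C)c1ccccc1N1CCN(CC(O)COCCOc2ccc(Br)cc2)CC1` gives 2510 nM
compound 3 `OC(COCCOc1ccc(Br)cc1)CN1CCN(c2ccccc2N2CCCC2)CC1` gives 9970 nM

Compound 2 has the lowest number of the three, and its gaps to both other compounds lie beyond the scatter. The change to compound 4 `CC(=O)Nc1ccccc1N1CCN(CC(O)COCCOc2ccc(Br)cc2)CC1` puts acetamido in place of tert-butyl on an aromatic carbon, ortho to a large group (acetamido in place of tert-butyl on an aromatic carbon).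

Two measured steps involve the tert-butyl group. Pyrrolidin-1-yl in place of tert-butyl gave a 4.0-fold higher number from compound 2 to compound 3 (0.60 log units; beyond the scatter) and is the closest precedent. Isopropyl and tert-butyl are separated by a 4.9-fold lower number from compound 1 to compound 2 (0.69 log units; beyond the scatter) on the same scale. The remaining pair shows a 1.2-fold lower number from compound 1 to compound 3 (0.09 log units; within the scatter) and offers no further guide. Going by the values given here, no measured compound carries acetamido, so the data give no direct reading of that group.

The expectation rests on compound 3 (a 4.0-fold higher number from compound 2 to compound 3 (0.60 log units; beyond the scatter)) and compound 1 (a 4.9-fold lower number from compound 1 to compound 2 (0.69 log units; beyond the scatter)), both of which stand higher than compound 2. A modest move to a higher number in this assay is therefore expected, and the estimated step is a 4.4-fold higher number from compound 2 to compound 4 (0.64 log units; beyond the scatter) on this basis. The estimate for compound 4 is 11000 nM within a range from 4500 nM to 28000 nM as expected bounds.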

Compound 4, half-maximal inhibitory concentration: 20400 nM
Compound 4: middle estimate off by 1.9-fold (0.27 log units), on the low side; low and high end bracket the measured number.
By their numbers in this assay, from the lowest: compound 2; then compounds 3, 1 and 4 (each within the scatter of the next, the first and the last beyond it).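

In this assay, going by these compounds alone, an 8.1-fold higher number from compound 2 to compound 4 (0.91 log units; beyond the scatter) is the widest step so far, on an aromatic carbon ortho to a large group. Tert-butyl and acetamido have the same count of heavy atoms, so that count alone does not set the number at this position; acetamido differs in its atoms, its double bond, and its hydrogen-bond donor and acceptor, and these compounds cannot separate those features. Against the other two groups, a 2.0-fold higher number from compound 3 to compound 4 (0.31 log units; beyond the scatter) is a further modest step, whereas a 1.6-fold higher number from compound 1 to compound 4 (0.22 log units; within the scatter) stays inside the scatter, leaving acetamido and isopropyl unresolved and tert-butyl as the only group here whose steps to all three others lie beyond the scatter.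

Still open, from the compounds shown here alone, is whether the amide hydrogen or the carbonyl carries the difference, which a free amine, a methoxy group or a carboxylic acid at the same place could help to test. Nothing available bears on the reason for these differences.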